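The compounds below may be only part of what the source reports. "The series", "measured", "known", "first", "only" and "open" are said of these compounds alone.

Compound 1 `COc1ccc(/C=C/C(=O)c2ccc(OC)c3c2OC(C)(C)C=C3)cc1OCCO` returns only a limit in a functional assay on HepG2 cells (Homo sapiens) for cytotoxicity, read by MTT assay (a higher number here means a weaker inhibitor, a lower number a stronger inhibitor), > 10000 nM. Compound 2 `C=CC(=O)Oc1cc(/C=C/C(=O)c2ccc(OC)c3c2OC(C)(C)C=C3)ccc1OC` gives 160 nM in this assay, and compound 3 `COc1cccc(C(=O)Oc2cc(/C=C/C(=O)c3ccc(OC)c4c3OC(C)(C)C=C4)ccc2OC)c1` gives 870 nM. Compound 3 therefore holds the higher of the two actual numbers, and its nearest neighbour is compound 2, through a 5.4-fold higher number from compound 2 to compound 3 (0.74 log units; beyond the scatter). Two large steps start from the limit of compound 1: an at least 62-fold lower number from compound 1 to compound 2 (1.79 log units; beyond the scatter) and an at least 11-fold lower number from compound 1 to compound 3 (1.06 log units; beyond the scatter). These concern the group on the oxygen, which compound 4 `COc1ccc(/C=C/C(=O)c2ccc(OC)c3c2OC(C)(C)C=C3)cc1OC(=O)c1ccc(Br)cc1` leaves as a carbonyl group.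

Among the measured compounds shown here, its only change is 4-bromophenyl in place of 3-methoxyphenyl on a carbonyl carbon, with 4-bromophenyl in place of 3-methoxyphenyl on a carbonyl carbon. For the measured compounds named here, no measured step exchanges one aromatic ring for another. The closest guide is the modest change at this same carbonyl carbon, a 5.4-fold higher number from compound 2 to compound 3 (0.74 log units; beyond the scatter), where vinyl gave way to 3-methoxyphenyl. Here one six-membered aromatic ring replaces another, so a smaller change is expected, with no clear direction. The expected step is a 1.1-fold lower number from compound 3 to compound 4 (0.04 log units; within the scatter). Compound 4 is estimated at 800 nM, with an expected range from 250 nM to 3000 nM.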

Compound 4, half-maximal inhibitory concentration: 680 nM
The estimate for compound 4 lay 1.2-fold (0.07 log units) above the measured number, within the range that was stated.
By their numbers in this assay, from the lowest: compound 2; then compounds 4 and 3 (each within the scatter of the next). At a limit, above all of these: compound 1.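

Among the compounds shown here, at this carbonyl carbon, the first exchange of one aromatic ring for another separates nothing in this assay: a 1.3-fold lower number from compound 3 to compound 4 (0.11 log units; within the scatter), so 3-methoxyphenyl and 4-bromophenyl cannot be told apart here. Compound 4 also shows that the gap to vinyl and the gain over 2-hydroxyethyl do not depend on the 3-methoxyphenyl group alone, with a 4.3-fold higher number from compound 2 to compound 4 (0.63 log units; beyond the scatter) and an at least 14-fold lower number from compound 1 to compound 4 (1.16 log units; beyond the scatter), both in the same direction as the matching steps of compound 3. For the compounds shown here, the second of these steps starts from a limit, the only result for compound 1: the limit of > 10000 nM in this assay, at which 1 of the 4 values shown sits.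

The compounds shown leave open how an aromatic ring bearing an amine or a carboxylic acid would read on this carbonyl carbon. They also leave open whether a longer chain in place of vinyl would fall with compound 2 or with compounds 3 and 4.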